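The compounds below may be only part of what the source reports. "The series", "measured", "known", "first", "only" and "open" are said of these compounds alone.

Working notes on the series. In an ADME assay on MRC5 cells (Homo sapiens) for cytotoxicity, read by fluorescence and resazurin assay, with a stated time of 3 days (a lower number here means a stronger inhibitor, a higher number a weaker inhibitor), compound 1 `Cc1cn(C2CCN(Cc3cccc(Oc4cccc(F)c4)c3)CC2)c(=O)[nH]c1=O` gives > 64000 nM, which is a limit of the assay and not a number. Compound 2 `COc1ccc(Oc2cccc(CN3CCC(n4cc(C)c(=O)[nH]c4=O)CC3)c2)cc1` gives 28000 nM and compound 3 `COc1cccc(Oc2cccc(CN3CCC(n4cc(C)c(=O)[nH]c4=O)CC3)c2)c1` gives 25300 nM. These two values lie within the scatter of each other, so compound 3 shares the low end of the measured numbers with compound 2.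

Compound 4 `Cc1cn(C2CCN(Cc3cccc(Oc4cccc(OC(F)(F)F)c4)c3)CC2)c(=O)[nH]c1=O` differs from compound 3 at one place trifluoromethyl in place of methyl on an oxygen on an aromatic ring, which reads as methoxy to trifluoromethoxy.

Among the compounds with values here, no measured step makes this exact change. The nearest is an at least 2.5-fold lower number from compound 1 to compound 3 (0.40 log units; beyond the scatter), which swaps fluoro and methoxy on an aromatic carbon. Its size is only a bound, and an at least 2.2-fold lower number from compound 1 to compound 2 (0.35 log units; beyond the scatter) is bounded in the same way. The step of a 1.1-fold lower number from compound 2 to compound 3 (0.04 log units; within the scatter) shows no effect beyond the scatter from moving the methoxy.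

Compound 4 keeps the methoxy oxygen but carries fluorine, as compound 1 does, so a small move towards a higher number is expected, probably within the scatter. The expected step is a 1.3-fold higher number from compound 3 to compound 4 (0.12 log units; within the scatter). In this assay, the estimate for compound 4 is 33000 nM, with an expected range of 15000 nM to 64000 nM.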

Compound 4, half-maximal inhibitory concentration: 5260 nM
For compound 4 the middle estimate is 6.3-fold (0.80 log units) above the measured one; measured number below the stated range.
By their numbers in this assay, from the lowest: compound 4; then compounds 3 and 2 (each within the scatter of the next). At a limit, above all of these: compound 1.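

At the place on an oxygen on an aromatic ring, the change from methyl to trifluoromethyl gives a 4.8-fold lower number from compound 3 to compound 4 (0.68 log units; beyond the scatter) in this assay, whereas relocating the methoxy had given only a 1.1-fold lower number from compound 2 to compound 3 (0.04 log units; within the scatter), so the identity of the group here separates these compounds where the methoxy shift did not. The 3-(trifluoromethoxy)phenyl compound also stands apart from the 4-methoxyphenyl compound, with a 5.3-fold lower number from compound 2 to compound 4 (0.73 log units; beyond the scatter), and fluorine alone does not mark the low end of the series: the fluoro compound and the trifluoromethoxy compound lie far apart, with an at least 12-fold lower number from compound 1 to compound 4 (1.08 log units; beyond the scatter). The size of that last step is only a bound, as the entry for compound 1 is a limit of the assay and not a number: the limit of > 64000 nM in this assay, at which 1 of the 4 values shown sits.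

From the compounds shown here alone, whether the lower number belongs to trifluoromethoxy specifically or would also appear with a difluoromethoxy, an ethoxy or a longer alkoxy chain remains open, and so does the outcome with an amine or a carboxylic acid at this place. The compounds shown also leave open whether trifluoromethoxy would give a similar step on the 4-methoxyphenyl compound in place of its methoxy group.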